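Urea-linked pyrazole series: methoxy to hydroxy step

The source may report more compounds than this note shows. Statements on the series, on what has been measured and on what is new or still open speak of the compounds shown alone.

Measured compounds:
compound 1, `O=C(Nc1cccc(-n2cc(-c3ccncc3)c(-c3ccc(Cl)c(O)c3)n2)c1)Nc1cccc(C(F)(F)F)c1`, 1950 nM
compound 2, `COc1cc(-c2nn(-c3cccc(NC(=O)Nc4ccc(Cl)c(Cl)c4)c3)cc2-c2ccncc2)ccc1Cl`, 1510 nM

Within the data shown here, both compounds share the same core and differ in two places at once, on the aryl ring bearing chlorine and on the terminal urea aryl ring, so no single step between them can be read. In a functional assay on SF-268 cells (Homo sapiens) for inhibition, read by sulforhodamine B assay, with a stated time of 48 h (on this read-out higher numbers stand for weaker inhibition of growth and lower numbers for stronger inhibition of growth), compound 1 gives 1950 nM and compound 2 gives 1510 nM; the two numbers lie within the usual scatter of each other, and compound 2 is not separated from compound 1 on this read-out.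

Compound 3, `O=C(Nc1cccc(-n2cc(-c3ccncc3)c(-c3ccc(Cl)c(O)c3)n2)c1)Nc1ccc(Cl)c(Cl)c1`, has not yet been measured. It keeps the terminal 3,4-dichlorophenyl urea of compound 2 and changes only one place: hydrogen in place of methyl on an oxygen on an aromatic ring, that is, methoxy to hydroxy, 4-chloro-3-methoxyphenyl to 4-chloro-3-hydroxyphenyl. Compound 1 already carries the hydroxy form beside a different urea aryl group, and its number is not separated from that of compound 2, so nothing here points to a step of any size in either direction. The expected step from compound 2 to compound 3 is a 1.0-fold lower number from compound 2 to compound 3 (0.00 log units; within the scatter), none beyond the scatter. Compound 3 is therefore estimated at 1500 nM in this assay, within 600 nM to 4000 nM.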

Compound 3, concentration for 50% growth inhibition: 1490 nM
Beside the measured number, compound 3's estimate is 1.0-fold (0.00 log units) above it; the range from low to high includes it.
By their numbers in this assay, from the lowest: compounds 3, 2 and 1 (each within the scatter of the next).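

In this assay, among these compounds, the step from methoxy to hydroxy can now be read on its own for the first time: a 1.0-fold lower number from compound 2 to compound 3 (0.01 log units; within the scatter), so with the 3,4-dichlorophenyl urea in place, hydrogen and methyl on an oxygen on an aromatic ring are not separated. Compound 3 also gives the first single-place read at the urea end, where 3,4-dichlorophenyl stands in place of 3-(trifluoromethyl)phenyl on an amide-type nitrogen: a 1.3-fold lower number from compound 1 to compound 3 (0.12 log units; within the scatter), again with no separation between the two groups. No measurement shown offers an explanation for either result.

The compounds shown carry only hydrogen or methyl on that oxygen, so it remains open whether a longer chain, or a chain ending in an amine, would give a number beyond the scatter. As far as these compounds go, at the amide-type nitrogen, a phenyl ring bearing a carboxylic acid is equally open, as is whether any change at either place would move the number in this assay away from the range these three compounds share.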